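A few compounds are considered here, and "the series" means these few. Any claim that something is new, unique, unknown or untested is made for them only; others in the source may bear on it.

Measured compounds in a physicochemical assay for lipophilicity; on this read-out higher numbers stand for higher lipophilicity and lower numbers for lower lipophilicity:
compound 1 `C=CCc1ccc(OC(=O)c2ccc(Cl)cc2)c(OC)c1` gives 2.79
compound 2 `C=CCc1ccc(OC(=O)c2ccc(C)cc2)c(OC)c1` gives 2.87
compound 3 `C=CCc1ccc(OC(=O)c2ccccc2C)c(OC)c1` gives 2.87

Compound 1 stands apart from compound 2 by a number 0.08 log units higher from compound 1 to compound 2 (within the scatter) and from compound 3 by a number 0.08 log units higher from compound 1 to compound 3 (within the scatter); neither step leaves the scatter. The unmeasured compound 4 `C=CCc1ccc(OC(=O)c2cccc(C)c2)c(OC)c1` differs from compound 1 in one place: 3-methylphenyl in place of 4-chlorophenyl on a carbonyl carbon. For the measured compounds named here, three measured steps bear on this change: methyl in place of chloro, a number 0.08 log units higher from compound 1 to compound 2 (within the scatter); 2-methylphenyl in place of 4-chlorophenyl, a number 0.08 log units higher from compound 1 to compound 3 (within the scatter); and 2-methylphenyl in place of 4-methylphenyl, no change at the digits printed from compound 2 to compound 3 (within the scatter). None of them exceeds the scatter. In this assay a step of the same kind is therefore expected, a number 0.08 log units higher from compound 1 to compound 4 (within the scatter), with no change beyond the scatter in either direction. Compound 4 is estimated at 2.87, with a range from 2.67 to 3.07.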

Compound 4, partition coefficient: 2.87
The estimate for compound 4 equals the measured number at the digits printed; measured number inside the range.
By their numbers in this assay, from the lowest: compounds 1, 2, 3 and 4 (each within the scatter of the next).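

In this assay, 3-methylphenyl in place of 4-chlorophenyl on a carbonyl carbon gives a step of the same size as the two earlier replacements (a number 0.08 log units higher from compound 1 to compound 4 (within the scatter)). The third placement of the methyl also separates from neither of the other two (no change at the digits printed from compound 3 to compound 4 (within the scatter) and no change at the digits printed from compound 2 to compound 4 (within the scatter)). All three methylphenyl compounds therefore lie within the scatter of one another, and of compound 1.

Open, from the compounds shown here alone, is whether an amine, a carboxylic acid or a longer chain on this phenyl ring would move the number beyond the scatter. Nothing available explains the flat read-out across these compounds.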